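This account rests on a few compounds, and the source may have more. Where it says the series, first, only, none or still open, it means among the compounds named here.

Compound 1 `CCCCCCc1c(F)c(N)c2c(=O)cc(-c3ccc(N)c(F)c3)oc2c1F` gives 21000 nM in a functional assay on HeLa cells (Homo sapiens) for cytotoxicity, read by neutral red uptake, with a stated time of 3 days; on this read-out higher numbers stand for weaker inhibition and lower numbers for stronger inhibition. Compound 2 `C[S+]([O-])c1c(F)c(N)c2c(=O)cc(-c3ccc(N)c(F)c3)oc2c1F` gives > 100000 nM, a limit of the assay. Compound 3 `Nc1ccc(-c2cc(=O)c3c(N)c(F)c(O)c(F)c3o2)cc1F` gives > 100000 nM, likewise a limit of the assay.

Going by the values given here, compound 3 therefore stands only at the limit of > 100000 nM in this assay, at which 2 of the 3 values shown sit, with no number of its own, and compound 1 holds the only numbered value among the three. Both changes made from compound 1 end at that limit: an at least 4.7-fold higher number from compound 1 to compound 2 (0.67 log units; beyond the scatter) and an at least 4.7-fold higher number from compound 1 to compound 3 (0.67 log units; beyond the scatter). The step from compound 2 to compound 3 reads a step that the two limits leave unreadable from compound 2 to compound 3.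

Compound 4 `COc1c(F)c(N)c2c(=O)cc(-c3ccc(N)c(F)c3)oc2c1F` differs from compound 3 by methyl in place of hydrogen on an oxygen on an aromatic ring. Among the compounds with values here, no measured step touches this oxygen; the two readable steps leave a hexyl chain and lead to the limit, and the change from hydroxy to methoxy is a different kind of alteration. Since the two steps away from compound 1 both went beyond the scatter toward weaker inhibition, compound 4 is expected to remain weak, and the expected step is a number no higher from compound 3 to compound 4 (the limit leaves the size open). Compound 4 is estimated at 100000 nM, in a range from 30000 nM to 300000 nM.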

Compound 4, half-maximal inhibitory concentration: 34000 nM
Compound 4: the middle estimate sits 2.9-fold (0.47 log units) above what was measured, and the stated range covers the measured number.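

With methyl on the oxygen of this aromatic ring, this assay gives a measured number rather than a limit, the first sign that a substituent other than hexyl on this aromatic carbon can do so (an at least 2.9-fold lower number from compound 3 to compound 4 (0.46 log units; beyond the scatter); an at least 2.9-fold lower number from compound 2 to compound 4 (0.46 log units; beyond the scatter)). Hexyl and methoxy cannot be told apart here (a 1.6-fold higher number from compound 1 to compound 4 (0.21 log units; within the scatter)), so leaving the hexyl chain does not by itself lead to the limit, as compounds 2 and 3 had suggested. The first two steps are bounds and not exact sizes, as compound 2 and compound 3 each rest on a limit: the limit of > 100000 nM in this assay, at which 2 of the 4 values shown sit.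

The compounds shown leave open how an amine, a carboxylic acid or an ethoxy group on this aromatic carbon would read. They also leave open whether a propyl chain would read like methoxy and hexyl.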